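This account rests on a few compounds, and the source may have more. Where it says the series, first, only, none or still open, it means among the compounds named here.

For the measured compounds named here, in a functional assay on HCT-116 cells (Homo sapiens) for antiproliferative activity, read by MTT assay, with a stated time of 48 h (a lower number here means a stronger inhibitor, a higher number a weaker inhibitor), compound 1 (`CC(=O)Nc1nc2ccc(-c3cnc(Cl)c(NS(=O)(=O)c4ccc(F)cc4)c3)cn2n1`) gives 9230 nM, the higher of the two numbers so far, which makes it the weaker inhibitor of the measured pair. Compound 2 (`CC(=O)Nc1nc2ccc(-c3cnc(Cl)c(NS(=O)(=O)c4ccc(C)cc4)c3)cn2n1`) gives 2650 nM. Compound 3 (`O=C(Nc1nc2ccc(-c3cnc(Cl)c(NS(=O)(=O)c4ccc(F)cc4)c3)cn2n1)C1CC1`) has not yet been measured and differs from compound 1 as follows: cyclopropyl in place of methyl on a carbonyl carbon. In words, this is cyclopropyl in place of methyl on a carbonyl carbon, so acetamido becomes (cyclopropylcarbonyl)amino. Going by the values given here, only one measured step exists, a 3.5-fold lower number from compound 1 to compound 2 (0.54 log units; beyond the scatter), which is modest and beyond the scatter. It swaps fluoro for methyl on an aromatic carbon, a different change, so it gives no size for this one, and no step beyond the scatter is expected. The expected step is a 1.2-fold lower number from compound 1 to compound 3 (0.09 log units; within the scatter). For compound 3 the estimated value is 7500 nM, with an expected range of 2500 nM to 20000 nM.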

Compound 3, half-maximal inhibitory concentration: 9980 nM
The estimate for compound 3 lay 1.3-fold (0.12 log units) below the measured number; the range from low to high includes it.
By their numbers in this assay, from the lowest: compound 2; then compounds 1 and 3 (each within the scatter of the next).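

In this assay, the carbonyl carbon of the acetamido group now has its first measured change, and swapping methyl for cyclopropyl gives a 1.1-fold higher number from compound 1 to compound 3 (0.03 log units; within the scatter), so compound 1 and compound 3 cannot be told apart. At this place, then, a cyclopropyl of 3 heavy atoms stands in for a methyl of 1 heavy atom with no step beyond the scatter, unlike the earlier swap on an aromatic carbon, which gave a 3.5-fold lower number from compound 1 to compound 2 (0.54 log units; beyond the scatter). Nothing measured here bears on why these two numbers stay so close.

Going by these compounds, whether an amine, a carboxylic acid or a longer chain such as butyl on this carbonyl carbon would give a step beyond the scatter remains open. Also open, on these data alone, is whether cyclopropyl would behave the same way on compound 2.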